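The compounds below may be only part of what the source reports. "The series", "measured", "known", "first", "only" and "open" are said of these compounds alone.

Measured compounds:
Compound 1 `CN(CCCc1ccccc1)C(=O)c1ccc[nH]1`: 40 nM
Compound 2 `CC(NC(=O)c1ccc[nH]1)c1ccccc1`: 1220 nM

Both were tested in an assay on mitochondria for inhibition of Amine oxidase [flavin-containing] A (Bos taurus), read by fluorescence; a higher number here means a weaker inhibitor, a lower number a stronger inhibitor. Of the two numbers, compound 2 has the higher one, and the gap to compound 1 lies beyond the usual scatter of repeated measurements, so compound 2 is the weaker inhibitor of the pair. The two compounds differ in more than one place, so no single change can be read from that gap.

Compound 3 `CC(c1ccccc1)N(C)C(=O)c1ccc[nH]1` has not yet been measured. It differs from compound 2 by methyl in place of hydrogen on an amide-type nitrogen. Among the measured compounds shown here, compound 1 also carries a methyl on its amide-type nitrogen, so the one comparison available points, loosely, towards a lower number for compound 3. The step from compound 2 to compound 3 is expected to be a moderate one towards a stronger inhibitor, a 3.1-fold lower number from compound 2 to compound 3 (0.48 log units; beyond the scatter). In this assay compound 3 is therefore estimated at 400 nM, with a likely range from 100 nM to 1500 nM.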

Compound 3, inhibition constant: 10 nM
For compound 3 the middle estimate is 40-fold (1.60 log units) above the measured one, and the stated range ends above it.
By their numbers in this assay, from the lowest: compound 3; then compound 1; then compound 2.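

Among the compounds shown here, compound 2 and compound 3 differ in one place only, so this is the first change in this assay that can be read on its own: methyl in place of hydrogen on an amide-type nitrogen gives a large step (a 120-fold lower number from compound 2 to compound 3 (2.09 log units; beyond the scatter)). In this pair, the amide hydrogen is therefore not needed for inhibition, and a single added carbon, with no ring and no net charge, moves the number far beyond the scatter. No measurement given here explains why so small a change has so large an effect.

From the compounds shown here alone, whether an ethyl group or a longer chain on this nitrogen would lower the number further or raise it again remains open. So does whether the same swap would have a similar effect on another core, such as that of compound 1.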